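Enlarging the chain end of compound 3

The source may report more compounds than this note shows. Statements on the series, on what has been measured and on what is new or still open speak of the compounds shown alone.

For the measured compounds named here, in a functional assay on MCF7 cells (Homo sapiens) for cytotoxicity, read by MTT assay, with a stated time of 72 h (a higher number here means a weaker inhibitor, a lower number a stronger inhibitor), compound 3 `CCCNC(=O)Nc1nc2ccc(-c3cnc(OC)c(NS(=O)(=O)c4ccc(F)cc4)c3)cn2n1` gives 360 nM and holds the lowest number of the three measured so far. Compound 1 `COc1ncc(-c2ccc3nc(NC(=O)N(C)C)nn3c2)cc1NS(=O)(=O)c1ccc(F)cc1` stands at 1560 nM and compound 2 `COc1ncc(-c2ccc3nc(NC(=O)NCC(=O)N4CCCC4)nn3c2)cc1NS(=O)(=O)c1ccc(F)cc1` at 2130 nM, and the step of a 1.4-fold higher number from compound 1 to compound 2 (0.14 log units; within the scatter) separates those two only within the scatter.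

Compound 4 `COc1ncc(-c2ccc3nc(NC(=O)NCCN4CCN(C)CC4)nn3c2)cc1NS(=O)(=O)c1ccc(F)cc1` differs from compound 3 by 4-methylpiperazin-1-yl in place of methyl on a saturated chain carbon, two bonds along the chain from an amide-type nitrogen on a saturated chain carbon, two bonds along the chain from an amide-type nitrogen.

Going by the values given here, compound 2 is the only measured compound with a ring on this chain, so the nearest evidence is the step of a 5.9-fold lower number from compound 2 to compound 3 (0.77 log units; beyond the scatter), read in reverse. The step of a 4.3-fold lower number from compound 1 to compound 3 (0.64 log units; beyond the scatter) is of similar, modest size. Among the compounds with values here, no measured compound carries the 4-methylpiperazin-1-yl group, so this transfer remains uncertain. A modest move toward a higher number is expected in this assay, with the estimated step being a 2.5-fold higher number from compound 3 to compound 4 (0.40 log units; beyond the scatter) as a working figure. The estimated value for compound 4 is 900 nM (250 nM to 3000 nM).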

Compound 4, half-maximal inhibitory concentration: 500 nM
The estimate for compound 4 lay 1.8-fold (0.26 log units) above the measured number; low and high end bracket the measured number.
By their numbers in this assay, from the lowest: compounds 3 and 4 (each within the scatter of the next); then compounds 1 and 2 (each within the scatter of the next).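

In this assay the chain end accepts 2-(4-methylpiperazin-1-yl)ethyl in place of propyl, with a 1.4-fold higher number from compound 3 to compound 4 (0.14 log units; within the scatter), so this position holds a far larger group carrying one six-membered non-aromatic ring with no change beyond the scatter. A ring on the chain therefore does not by itself go with the higher number of compound 2: the series shows a 4.3-fold lower number from compound 2 to compound 4 (0.63 log units; beyond the scatter) and also a 3.1-fold lower number from compound 1 to compound 4 (0.49 log units; beyond the scatter), which sets the 2-(4-methylpiperazin-1-yl)ethyl urea apart from both of those compounds. No measurement shown here accounts for these steps.

On these data alone, whether the ring matters, or only the chain end, stays open; a morpholin-4-yl or dimethylamino group on the same ethyl chain would test this. A longer chain ending in 4-methylpiperazin-1-yl would show how far the tolerance at this position extends.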